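Swapping 4-methylphenyl for 4-chloropyridin-2-yl in the series

This account rests on a few compounds, and the source may have more. Where it says the series, first, only, none or still open, it means among the compounds named here.

Measured in a functional assay on MCF7 cells (Homo sapiens) for inhibition, read by CCK-8 assay, with a stated time of 48 h (a lower number here means a stronger inhibitor of growth, a higher number a weaker inhibitor of growth), both values being limits:
compound 1 `Cc1ccccc1Nc1nc(NC2CCCCC2)ncc1Cl`: > 100000 nM
compound 2 `Cc1ccc(Nc2ncc(Cl)c(Nc3ccccc3C)n2)cc1`: > 100000 nM

From the compounds shown here alone, compound 2 gives only a limit of the assay, > 100000 nM, so its true place on the scale is unknown. Compound 1 likewise gives only a limit. The evidence so far consists of the limit of > 100000 nM in this assay, at which 2 of the 2 values shown sit.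

Compound 3 `Cc1ccccc1Nc1nc(Nc2cc(Cl)ccn2)ncc1Cl` has not yet been measured. It carries 4-chloropyridin-2-yl in place of 4-methylphenyl on a nitrogen on an aromatic ring.

Among the measured compounds shown here, the only measured step at this place is a step that the two limits leave unreadable from compound 1 to compound 2. For the measured compounds named here, it offers no size to carry over to the new change, and no measured compound yet has a number in this assay. Compound 3 is therefore expected to remain a weak inhibitor of growth, and another limit is quite possible. If a number does appear, it can only point towards stronger inhibition. The estimated step is an at least 2.0-fold lower number from compound 2 to compound 3 (0.30 log units; that floor lies within the scatter). The expected value for compound 3 is 50000 nM, with an estimated range from 10000 nM to 150000 nM.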

Compound 3, concentration for 50% growth inhibition: > 100000 nM
Compound 3 was reported as a limit; the forecaster's own chance of this, stated with the estimate: 55%; middle value at least 2.0-fold (0.30 log units) away from the limit.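

In this assay compound 3 gives > 100000 nM, a limit of the assay and not a number. The steps among compound 1, compound 2 and compound 3 cannot be read. The compounds shown leave open whether cyclohexyl, 4-methylphenyl and 4-chloropyridin-2-yl on a nitrogen on an aromatic ring differ at all in growth inhibition.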